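Acetamido Variation on a Tryptamine-Linked Piperidine Series

The source may hold more compounds than are shown below. What is called first, only, known or untested is meant among the compounds shown, and "the series" means these compounds.

Measured compounds:
- compound 1 `C[C@@H](NCC1CCN(CCCc2c[nH]c3ccc(-n4cnnc4)cc23)CC1)c1ccccc1`: 14 nM
- compound 2 `O[C@@H]1Cc2ccccc2[C@H]1NC1CCN(CCCc2c[nH]c3ccc(-n4cnnc4)cc23)CC1`: 210 nM
- compound 3 `c1ccc2c(c1)CCC2NC1CCN(CCCc2c[nH]c3ccc(-n4cnnc4)cc23)CC1`: 280 nM

In an assay on CHO cells for displacement of a labelled ligand from 5-hydroxytryptamine receptor 1B (Homo sapiens) (a lower number here means a stronger inhibitor, a higher number a weaker inhibitor), compound 1 gives 14 nM, the lowest number among the three measured compounds. The other two lie well away from it: a 15-fold higher number from compound 1 to compound 2 (1.18 log units; beyond the scatter) and a 20-fold higher number from compound 1 to compound 3 (1.30 log units; beyond the scatter). Between those two, a 1.3-fold higher number from compound 2 to compound 3 (0.12 log units; within the scatter), so compound 2 and compound 3 cannot be told apart on these numbers.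

Compound 4 `CC(=O)Nc1ccc([C@H](C)NCC2CCN(CCCc3c[nH]c4ccc(-n5cnnc5)cc34)CC2)cc1` is not yet measured. It differs from compound 1 in one place: 1-(4-acetamidophenyl)ethyl in place of 1-phenylethyl on an amine nitrogen. The carbon framework around the amine is kept, and only the aromatic ring of the 1-phenylethyl group carries the new acetamido group.

Going by the values given here, none of the measured steps tests this change directly. The steps from compound 1 to compound 2 and to compound 3 replace the whole ((1-phenylethyl)amino)methyl arm and were both large, which shows that this region is sensitive, but they say nothing about a substituent on an otherwise unchanged 1-phenylethyl group. The shared core and the linker are untouched in compound 4.

Compound 4 is therefore expected to stay close to compound 1, with a step of a 1.4-fold higher number from compound 1 to compound 4 (0.15 log units; within the scatter) in this assay, and its estimated value is 20 nM (range 5 nM to 80 nM).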

Compound 4, half-maximal inhibitory concentration: 9.3 nM
Estimate against measurement, compound 4: 2.2-fold (0.33 log units) above; measured number inside the range.
By their numbers in this assay, from the lowest: compounds 4 and 1 (each within the scatter of the next); then compounds 2 and 3 (each within the scatter of the next).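

In this assay the exchange of 1-phenylethyl for 1-(4-acetamidophenyl)ethyl on the amine nitrogen gives a 1.5-fold lower number from compound 1 to compound 4 (0.18 log units; within the scatter) and leaves the two compounds indistinguishable on these numbers. The earlier steps shown here had replaced the whole ((1-phenylethyl)amino)methyl arm and showed only that this region responds to such a replacement; this step shows that the 1-phenylethyl group can carry an acetamido group on its aromatic ring, with 12 heavy atoms in place of 8 and a hydrogen-bond donor and acceptor added, without a shift beyond the scatter. Nothing available here accounts for this result.

From the compounds shown here alone, whether the ring would accept other groups in place of acetamido, such as an amine, a carboxylic acid or a methoxy group, remains open. Also open, going by these compounds, is whether the same acetamido group would be accepted on the aromatic ring of the 2,3-dihydro-1H-inden-1-yl group of compound 3, and whether the opposite configuration at the defined stereocentre of the 1-(4-acetamidophenyl)ethyl group would give a similar number.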